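From compound 3 to compound 4: an aryl exchange

A few compounds are considered here, and "the series" means these few. Any claim that something is new, unique, unknown or untested is made for them only; others in the source may bear on it.

In a functional assay on PC-3 cells (Homo sapiens) for cytotoxicity, read by MTT assay, with a stated time of 72 h (on this read-out higher numbers stand for weaker inhibition and lower numbers for stronger inhibition), compound 1 `Cc1cc(=O)n(-c2ccc(F)cc2)nc1C(=O)Nc1ccc(Oc2ncnc3[nH]ccc23)cc1` gives > 60000 nM, which is a limit of the assay and not a number. Compound 3 `Cc1cc(=O)n(-c2ccccc2OC(F)(F)F)nc1C(=O)Nc1ccc(Oc2ncnc3[nH]ccc23)cc1` gives 22500 nM, the higher of the two actual numbers, with compound 2 `Cc1ccc(-n2nc(C(=O)Nc3ccc(Oc4ncnc5[nH]ccc45)cc3)c(C)cc2=O)cc1` at 9610 nM. Compound 4 `Cc1cc(=O)n(-c2cccc(C(F)(F)F)c2)nc1C(=O)Nc1ccc(Oc2ncnc3[nH]ccc23)cc1` carries 3-(trifluoromethyl)phenyl in place of 2-(trifluoromethoxy)phenyl on an aromatic nitrogen.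

All three measured steps alter this same aryl group. The first is an at least 6.2-fold lower number from compound 1 to compound 2 (0.79 log units; beyond the scatter), and the second is an at least 2.6-fold lower number from compound 1 to compound 3 (0.42 log units; beyond the scatter); both start from a limit. Among the compounds with values here, the only step between two actual numbers is a 2.3-fold higher number from compound 2 to compound 3 (0.37 log units; beyond the scatter), and it is the closest guide. Changes here have moved the number modestly, and the steps from compound 2 and to compound 2 run in opposite directions, so no direction is favoured. No step beyond the scatter is therefore expected in this assay. The expected change is a 1.3-fold lower number from compound 3 to compound 4 (0.10 log units; within the scatter). Compound 4 is estimated at 18000 nM, with an expected range of 7000 nM to 50000 nM.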

Compound 4, half-maximal inhibitory concentration: 3460 nM
Beside the measured number, compound 4's estimate is 5.2-fold (0.72 log units) above it; measured number below the stated range.
By their numbers in this assay, from the lowest: compound 4; then compound 2; then compound 3. At a limit, above all of these: compound 1.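

In this assay, within the data shown here, this aryl exchange shows that the group on the aromatic nitrogen can move the number further than the only earlier step between two actual numbers suggested: a 6.5-fold lower number from compound 3 to compound 4 (0.81 log units; beyond the scatter), against a 2.3-fold higher number from compound 2 to compound 3 (0.37 log units; beyond the scatter). Among these compounds, the 3-(trifluoromethyl)phenyl group also outdoes 4-methylphenyl, the best aryl group among the earlier compounds, with a 2.8-fold lower number from compound 2 to compound 4 (0.44 log units; beyond the scatter), which gives compound 4 the lowest number of the series. There is also an at least 17-fold lower number from compound 1 to compound 4 (1.23 log units; beyond the scatter), but this step starts from compound 1, whose value is a limit of the assay and not a number: the limit of > 60000 nM in this assay, at which 1 of the 4 values shown sits.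

The exchange from compound 3 to compound 4 alters both the substituent and its place on the phenyl ring, and the compounds shown do not separate these two changes. Going by these compounds, whether a nitrile or an amine in place of the trifluoromethyl group would keep the number of compound 4 also stays open.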